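Furan to thiophene on a nitro-bearing benzoxazolone amide

A few compounds are considered here, and "the series" means these few. Any claim that something is new, unique, unknown or untested is made for them only; others in the source may bear on it.

Compounds measured so far:
- compound 1 `O=C(Cn1c(=O)oc2cc([N+](=O)[O-])ccc21)Nc1ccccc1`: 26.4%
- compound 2 `O=C(Cn1c(=O)oc2ccccc21)NCc1cccs1`: 49.1%
- compound 3 `O=C(Cn1c(=O)oc2cc([N+](=O)[O-])ccc21)NCc1ccco1`: 60.1%

All three share a core with an acetamide arm, and each was tested in an ADME assay on RAW264.7 cells (Mus musculus) for cytotoxicity, read by MTT assay, with a stated time of 72 h, tested at 100 uM; a higher number here means a stronger effect of the compound at the concentration tested, a lower number a weaker effect. Compound 3 stands highest of the three numbers in this assay, with compound 2 nearest, a number lower by more than the usual scatter, and compound 1 furthest. Among the compounds with values here, the one step that can be read directly, a number 33.7 percentage points higher from compound 1 to compound 3 (beyond the scatter), shows that swapping the amide substituent can move the read-out a long way.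

Compound 4 `O=C(Cn1c(=O)oc2cc([N+](=O)[O-])ccc21)NCc1cccs1` has not yet been measured. It differs from compound 3 by one change: thiophen-2-yl in place of furan-2-yl on a saturated chain carbon bound to an amide-type nitrogen. Within the data shown here, no measured step covers this exact swap; the step from compound 1 to compound 3 concerns a different pair of groups and says nothing direct about furan against thiophene. Compound 2 carries the same thiophene group on a core without the nitro group and gives 49.1%, while compound 3 gives 60.1%. With two five-membered aromatic groups of the same size and acceptor count exchanged, a step of a number 5.1 percentage points lower from compound 3 to compound 4 (within the scatter) is expected, that is, nothing clearly beyond the scatter. Compound 4 is therefore estimated at 55%, with a likely range from 40% to 70%.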

Compound 4, a percentage reported as inhibition, at one concentration (the size of the read-out at that concentration, not a potency): 41%
Compound 4: the middle estimate sits 14 percentage points above what was measured; the range from low to high includes it.
By their numbers in this assay, from the lowest: compound 1; then compounds 4 and 2 (each within the scatter of the next); then compound 3.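

In this assay, furan-2-yl and thiophen-2-yl have the same heavy-atom count and ring size, yet exchanging them on the nitro-bearing core gives a number 19.1 percentage points lower from compound 3 to compound 4 (beyond the scatter), so the ring's hetero atom matters at this position. The amide substituent's effect also depends on that ring: a number 14.6 percentage points higher from compound 1 to compound 4 (beyond the scatter) is a smaller rise than a number 33.7 percentage points higher from compound 1 to compound 3 (beyond the scatter), while adding nitro to the thiophene compound gives a number 8.1 percentage points lower from compound 2 to compound 4 (within the scatter), a step that cannot be told from no change. Nothing available here accounts for the difference between the two rings.

From the compounds shown here alone, whether nitro has the same small effect alongside furan-2-yl remains open. So does the separate contribution of the linking carbon, which a benzyl group on the amide nitrogen could address, and the effect of a longer chain between that nitrogen and the ring.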